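Notes on the step from compound 3 to compound 4

The source may hold more compounds than are shown below. What is called first, only, known or untested is meant among the compounds shown, and "the series" means these compounds.

Measured in an ADME assay for permeability, using PAMPA, with a stated time of 4 h, at pH 5.5 (on this read-out lower numbers stand for lower permeability and higher numbers for higher permeability), so far:
Compound 1 `NC/C=C/CN(C[C@H]1Cc2ncccc2CN1)[C@H]1CCCc2cccnc21` gives 2 nm/s
Compound 2 `NC(=O)NCCCCN(C[C@H]1Cc2ncccc2CN1)[C@H]1CCCc2cccnc21` gives 7 nm/s
Compound 3 `CN(CCCCN(C[C@H]1Cc2ncccc2CN1)[C@H]1CCCc2cccnc21)C1CCC(F)(F)CC1` gives 15 nm/s

Among these three numbers, compound 3 stands highest (15 nm/s). Compound 4 `c1cnc2c(c1)CN[C@@H](CN(CCCCNC1COC1)[C@H]1CCCc3cccnc31)C2` differs from it by a single change (a group of 5 heavy atoms (3 carbon, 1 nitrogen, 1 oxygen; one four-membered non-aromatic ring with 1 hetero atom) in place of a group of 10 heavy atoms (7 carbon, 1 nitrogen, 2 fluorine; one six-membered non-aromatic ring of carbon only), on a saturated chain carbon, four bonds along the chain from an amine nitrogen). Among the measured compounds shown here, two measured steps bear on this change. The closer one is a 2.1-fold higher number from compound 2 to compound 3 (0.33 log units; beyond the scatter) and it brought in the same group that leaves here. The other is a 3.5-fold higher number from compound 1 to compound 2 (0.54 log units; beyond the scatter) and it involves neither group of the present change, though it does show that both compounds lacking the departing group sit lower than compound 3. Both steps are modest. For the measured compounds named here, no measured compound carries the (oxetan-3-yl)amino group, so what it does in this assay is not known from these data, and only the departure of the other group has any precedent. Reading a 2.1-fold higher number from compound 2 to compound 3 (0.33 log units; beyond the scatter) in reverse, a modest fall of similar size is expected, with some uncertainty from the unseen group. The expected step is a 3.0-fold lower number from compound 3 to compound 4 (0.48 log units; beyond the scatter) and it is of modest size. The estimate for compound 4 is 5 nm/s (expected range 2 nm/s to 13 nm/s).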

Compound 4, apparent permeability: 7 nm/s
Beside the measured number, compound 4's estimate is 1.4-fold (0.15 log units) below it; low and high end bracket the measured number.
By their numbers in this assay, from the lowest: compound 1; then compounds 2 and 4 (each within the scatter of the next); then compound 3.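

In this assay, the (oxetan-3-yl)amino group gives up the gain seen with the group it replaces: a 2.1-fold lower number from compound 3 to compound 4 (0.33 log units; beyond the scatter), and no change at the digits printed from compound 2 to compound 4 (within the scatter). Oxetan-3-yl and carbamoyl on the amine nitrogen therefore cannot be told apart in this read-out, and a ring in the entering group does not by itself keep the number at the level of compound 3, which remains the highest of the four. Compound 1 remains the lowest, with a 3.5-fold higher number from compound 1 to compound 4 (0.54 log units; beyond the scatter), so the butyl-chain compound carrying the oxetane stays clear of the compound with the 3-aminoprop-1-en-1-yl group, and no measured evidence speaks to what lies behind any of these steps.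

The change from compound 3 to compound 4 swaps the whole group at once, so the share of the ring, its two fluorines and the methyl on the amine nitrogen remains unresolved. A plain cyclohexyl, a tetrahydropyran-4-yl or an oxetan-3-yl carrying that methyl on the same nitrogen would be needed to separate these parts.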